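This account rests on a few compounds, and the source may have more. Where it says the series, first, only, none or still open, it means among the compounds named here.

Of the compounds shown here, three built on the same core have been measured in an ADME assay on MT4 cells (Homo sapiens) for cytotoxicity, read by MTT assay; a higher number here means that more compound is tolerated, a lower number that less compound is tolerated. Compound 1 `O=C1c2ccccc2C(=O)N1CCOC(=S)N(C(=O)c1ccc(C(F)(F)F)cc1)c1ccc(Cl)cc1` gives 10000 nM. Compound 2 `O=C1c2ccccc2C(=O)N1CCOC(=S)N(C(=O)c1ccc(Br)cc1)c1ccc(Br)cc1` gives 73000 nM, and compound 3 `Cc1ccc(C(=O)N(C(=S)OCCN2C(=O)c3ccccc3C2=O)c2ccc(C)cc2)cc1` gives 83000 nM. Of these three numbers, compound 1 stands lowest, and its gaps to compound 2 and to compound 3 are both beyond the usual scatter of this assay, while the two higher values lie within the scatter of each other. No two of the measured compounds differ in only one place, so no single step can be read off directly.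

Compound 4 `O=C1c2ccccc2C(=O)N1CCOC(=S)N(C(=O)c1ccc(Cl)c(Cl)c1)c1ccc(Cl)cc1` has not yet been measured in this assay. It differs from compound 1 in one place: 3,4-dichlorophenyl in place of 4-(trifluoromethyl)phenyl on a carbonyl carbon. The group with three fluorines on one carbon leaves, and a ring bearing two chlorines enters, on the carbonyl carbon whose other neighbour is the amide-type nitrogen.

Going by the values given here, since no measured pair covers a change of this kind, the expectation rests on the spread already seen. Compound 2 reaches 73000 nM and compound 3 reaches 83000 nM, whereas compound 1 sits at 10000 nM. Compound 4 is expected to move upward by a small step, a 1.8-fold higher number from compound 1 to compound 4 (0.26 log units; within the scatter), hardly beyond the scatter. The estimate for compound 4 is 18000 nM, within a range from 6000 nM to 55000 nM.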

Compound 4, half-maximal cytotoxic concentration: 35000 nM
Compound 4: the middle estimate sits 1.9-fold (0.29 log units) below what was measured; low and high end bracket the measured number.
By their numbers in this assay, from the lowest: compound 1; then compound 4; then compounds 2 and 3 (each within the scatter of the next).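

In this assay, going by these compounds alone, 3,4-dichlorophenyl in place of 4-(trifluoromethyl)phenyl on a carbonyl carbon whose other neighbour is the amide-type nitrogen gives a 3.5-fold higher number from compound 1 to compound 4 (0.54 log units; beyond the scatter) and is the only single-place change available in this small set. Within the data shown here, although modest, the step lies beyond the scatter, which shows that changing this one group, with the rest of compound 1 held constant, is enough to shift the tolerated concentration, something the earlier compounds could not show because they differ from one another in more than one place. The data offer no measured property that would account for the direction or size of this shift.

Among these compounds, it remains open how an amine, a carboxylic acid or a longer chain carried on the aromatic ring at this carbonyl carbon would affect the number, since the two groups compared here are the only pair that isolates this position. It is also unresolved whether the same exchange would produce a step of similar size if the group on the amide-type nitrogen were different, as a single pair cannot establish a trend.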